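The source may hold more compounds than are shown below. What is called first, only, known or untested is meant among the compounds shown, and "the series" means these compounds.

The series shares the core of compound 1 `CCN(C(=O)c1cc(C)ccc1-n1nccn1)[C@@H](C)Cn1ccc(-c2ccc(F)cn2)n1`, which in a functional assay on cells for antagonist activity at Orexin receptor type 2 (Homo sapiens), read by fluorescence and calcium flux, with a stated time of 30 min (on this read-out lower numbers stand for stronger inhibition and higher numbers for weaker inhibition), gives 1.61 nM, the lowest number of the three measured. Compound 2 `CCN(C(=O)c1cc(C)ccc1-n1nccn1)[C@H](C)Cn1ccc(-c2ccc(F)cn2)n1` gives 250 nM in this assay, and compound 3 `Cc1ccc(-n2nccn2)c(C(=O)N(C)CCn2ccc(-c3ccc(F)cn3)n2)c1` gives 11.9 nM. For the measured compounds named here, the only single-place step measured is a 160-fold higher number from compound 1 to compound 2 (2.19 log units; beyond the scatter), a step whose sole structural basis is the fact that compounds 1 and 2 differ only in the configuration as drawn. Compound 1 and compound 3 differ in more than one place, so their values are taken only as they stand: compound 3 sits above compound 1 by a margin beyond the scatter.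

Compound 4 `Cc1ccc(-n2nccn2)c(C(=O)N[C@@H](C)Cn2ccc(-c3ccc(F)cn3)n2)c1` is compound 1 with hydrogen in place of ethyl on an amide-type nitrogen. Going by the values given here, no measured step alters the group on the amide-type nitrogen, so the measured steps give no direct read on this change; the large step from compound 1 to compound 2 concerns configuration alone. The expectation is a weaker number, with wide uncertainty. Compound 4 is expected to give 40 nM in this assay, estimated between 6 nM and 300 nM. The estimated step is therefore a 25-fold higher number from compound 1 to compound 4 (1.40 log units; beyond the scatter).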

Compound 4, half-maximal inhibitory concentration: 58.4 nM
Beside the measured number, compound 4's estimate is 1.5-fold (0.16 log units) below it, and the stated range covers the measured number.
By their numbers in this assay, from the lowest: compound 1; then compound 3; then compound 4; then compound 2.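

In this assay, hydrogen in place of ethyl on the amide-type nitrogen, with the configuration of compound 1 kept, gives a 36-fold higher number from compound 1 to compound 4 (1.56 log units; beyond the scatter), so the group on this nitrogen counts for much of the low number of compound 1. For the compounds shown here, until now the only single-place step concerned configuration alone, and this is the first to show that a change of substituent at this nitrogen also moves the number well beyond the scatter. Nothing recorded for these compounds bears on why the ethyl has this effect.

As far as these compounds go, whether a propyl or a cyclopropyl on this nitrogen would keep, improve or lose the number of compound 1 remains open. Also open, from the compounds shown here alone, is whether hydrogen in place of ethyl would give a step of similar size in the configuration of compound 2.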